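A few compounds are considered here, and "the series" means these few. Any claim that something is new, unique, unknown or untested is made for them only; others in the source may bear on it.

Measured so far in an assay on CHO-K1 cells for displacement of a labelled ligand from adenosine receptor A1 (Homo sapiens), read by scintillation counting, with a stated time of 60 min; on this read-out higher numbers stand for weaker inhibition and lower numbers for stronger inhibition:

compound 1 `Nc1nc(N/N=C/c2ccc(N3CCCC3)cc2)nc2c1ncn2[C@@H]1O[C@H](CO)[C@@H](O)[C@H]1O` gives 5.1 nM
compound 2 `Nc1nc(N/N=C/c2ccc(-c3ccc(Br)cc3)o2)nc2c1ncn2[C@@H]1O[C@H](CO)[C@@H](O)[C@H]1O` gives 4.5 nM
compound 3 `Nc1nc(N/N=C/c2ccc(N(c3ccccc3)c3ccccc3)cc2)nc2c1ncn2[C@@H]1O[C@H](CO)[C@@H](O)[C@H]1O` gives only a limit of the assay, > 10000 nM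

Compound 1 and compound 2 sit within the scatter of each other, so no order between them can be read. For compound 3 a limit alone is recorded, (the limit of > 10000 nM in this assay, at which 1 of the 3 values shown sits).

Compound 4 `Nc1nc(N/N=C/C2CCCC2)nc2c1ncn2[C@@H]1O[C@H](CO)[C@@H](O)[C@H]1O` is not yet measured. It differs from compound 1 in one place: cyclopentyl in place of 4-(pyrrolidin-1-yl)phenyl on a carbon with a double bond to nitrogen. Compound 1 and compound 2 each carry an aromatic ring in that place; compound 4 has none. A step beyond the scatter toward weaker inhibition is expected in this assay, the expected step being a 16-fold higher number from compound 1 to compound 4 (1.20 log units; beyond the scatter). Compound 4 is estimated at 80 nM, with a range from 15 nM to 500 nM.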

Compound 4, inhibition constant: 5.6 nM
Compound 4: middle estimate off by 14-fold (1.15 log units), on the high side; the measured number lies below the stated range.
By their numbers in this assay, from the lowest: compounds 2, 1 and 4 (each within the scatter of the next). At a limit, above all of these: compound 3.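

In this assay, an aromatic ring on the carbon with a double bond to nitrogen proves unnecessary for a low number: cyclopentyl in place of 4-(pyrrolidin-1-yl)phenyl gives a 1.1-fold higher number from compound 1 to compound 4 (0.04 log units; within the scatter) in this series. The change also removes the ring nitrogen and its hydrogen-bond acceptor without moving the number beyond the scatter. Nothing shown gives a cause for this.

Open, from the compounds shown here alone, is whether an open chain such as n-pentyl, or cyclopentyl carrying an amine or a carboxylic acid, holds this number. Compound 3, which carries an aromatic ring, gives only a limit, > 10000 nM, so an aromatic ring alone does not secure a low number.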